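Compound 4 and the side group of compound 1

The compounds below may be only part of what the source reports. "The series", "measured", "known", "first", "only" and "open" are said of these compounds alone.

In a functional assay on V79 cells (Cricetulus griseus) for cytotoxicity, read by colony formation (a higher number here means a weaker inhibitor, a lower number a stronger inhibitor), compound 1 `CNCC1(C)CCN(c2c(F)cc3c(=O)c(C(=O)O)cn(C4CC4)c3c2Cl)C1` gives 23 ug/mL, the lowest of three numbers. Compound 2 `CNCC1(C)CCN(c2c(F)cc3c(=O)c(C(=O)O)cn(C4CC4)c3c2OC)C1` gives 120 ug/mL, and compound 3 `CNCC1(C)CCN(c2c(F)cc3c(=O)c(C(=O)O)cn(C4CC4)c3c2C(F)(F)F)C1` gives 230 ug/mL. Methoxy in place of chloro is a 5.2-fold higher number from compound 1 to compound 2 (0.72 log units; beyond the scatter), and trifluoromethyl in place of chloro is a 10-fold higher number from compound 1 to compound 3 (1.00 log units; beyond the scatter). Trifluoromethyl in place of methoxy is a 1.9-fold higher number from compound 2 to compound 3 (0.28 log units; within the scatter).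

Compound 4 `NC1CCN(c2c(F)cc3c(=O)c(C(=O)O)cn(C4CC4)c3c2Cl)CC1` keeps the chloro group and instead carries 4-aminopiperidin-1-yl in place of 3-methyl-3-((methylamino)methyl)pyrrolidin-1-yl on an aromatic carbon. None of the three measured steps touches this group, since each one changes only the chloro, methoxy or trifluoromethyl group, so they give no size or direction for this change. The expectation therefore starts from compound 1 at 23 ug/mL, and no step beyond the scatter is expected, though this remains poorly constrained. The estimate means a 1.3-fold higher number from compound 1 to compound 4 (0.12 log units; within the scatter), as an expected step. Compound 4 is expected at 30 ug/mL, with an estimated range of 8 ug/mL to 110 ug/mL.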

Compound 4, half-maximal inhibitory concentration: 18 ug/mL
Compound 4: the middle estimate sits 1.7-fold (0.22 log units) above what was measured; measured number inside the range.
By their numbers in this assay, from the lowest: compounds 4 and 1 (each within the scatter of the next); then compounds 2 and 3 (each within the scatter of the next).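

In this assay, 4-aminopiperidin-1-yl in place of 3-methyl-3-((methylamino)methyl)pyrrolidin-1-yl gives a 1.3-fold lower number from compound 1 to compound 4 (0.11 log units; within the scatter). Within the data shown here, this is the first reading at this position, on an aromatic carbon ortho to a chloro group and ortho to a fluoro group, and with the chloro group held, a six-membered ring of 7 heavy atoms and a five-membered ring of 9 heavy atoms cannot be told apart here. Nothing available explains why these two side groups read alike.

From the compounds shown here alone, compound 2 and compound 3 carry only the original side group, so it remains open whether 4-aminopiperidin-1-yl would read the same alongside methoxy or trifluoromethyl. Also open, going by these compounds, is how a piperazine or a longer aminoalkyl chain would read at this position.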